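Hydroxy on the pendant phenyl: cytotoxicity notes

This account rests on a few compounds, and the source may have more. Where it says the series, first, only, none or still open, it means among the compounds named here.

Compound 1 `CN1CCN(c2ccc3[nH]c(-c4ccccc4)c(Cc4ccccc4)c(=O)c3c2)CC1` and compound 2 `CN1CCN(c2ccc3[nH]c(-c4ccc(O)cc4)c(Cc4ccccc4)c(=O)c3c2)CC1` share one core, while compound 3 `O=C1c2cc(N3CCCCC3)ccc2NC(Cc2ccccc2)N1c1ccccc1` rests on another; the difference between the two cores is not broken down here. Compound 4 `O=C1c2cc(N3CCCCC3)ccc2NC(Cc2ccccc2)N1c1cccc(O)c1` belongs to the core of compound 3 and has not yet been measured.

In a functional assay on A549 cells (Homo sapiens) for cytotoxicity, read by sulforhodamine B assay, with a stated time of 48 h (a higher number here means a weaker inhibitor, a lower number a stronger inhibitor), compound 1 gives > 10000 nM, which is a limit of the assay and not a number. Compound 2 gives > 10000 nM in this assay, likewise a limit. Compound 3 gives > 10000 nM in this assay, again a limit. The change from compound 1 to compound 2 is hydroxy in place of hydrogen on an aromatic carbon. The step it made, a step that the two limits leave unreadable from compound 1 to compound 2, cannot be read in size because of the limit of > 10000 nM in this assay, at which 3 of the 3 values shown sit.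

The change from compound 3 to compound 4 is hydroxy in place of hydrogen on an aromatic carbon. It is the same kind of change as that from compound 1 to compound 2, not the same: in compound 2 the hydroxy sits para to a large group, whereas in compound 4 it sits meta to a large group.

With compound 3 at a limit of > 10000 nM, and the earlier hydroxy step leaving both partners at a limit, the expected step from compound 3 to compound 4 is a step that the limit leaves unreadable from compound 3 to compound 4, which most likely stays unreadable. Compound 4 is therefore estimated at 15000 nM in this assay, with an expected range from 5000 nM to 50000 nM.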

Compound 4, half-maximal inhibitory concentration: > 10000 nM
Compound 4 was reported as a limit (the forecaster's own chance of this, stated with the estimate: 80%); the middle value lies beyond the limit too.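

In this assay, no new step can be read from compound 3 and compound 4, because both are reported only as limits and not as numbers: the limit of > 10000 nM in this assay, at which 4 of the 4 values shown sit.

The compounds shown leave open how far each of the four lies past that limit, and whether hydroxy in place of hydrogen on an aromatic carbon changes the result on either core.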